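The source may report more compounds than this note shows. Statements on the series, on what has been measured and on what is new or still open speak of the compounds shown alone.

Measured in a functional assay on HCT-116 cells (Homo sapiens) for inhibition; a higher number here means a weaker inhibitor of growth, a lower number a stronger inhibitor of growth:
compound 1 `COc1cc(/C=C/C(=O)c2cccc(-n3cc(-c4ccc(Cl)cc4)[nH]c3=O)c2)cc(OC)c1OC`, 1390 nM
compound 2 `O=C(/C=C/c1cccc(O)c1)c1cccc(-n2cc(-c3ccc(Cl)cc3)[nH]c2=O)c1`, 1230 nM

Compound 1 has the highest of the two numbers, yet compound 2 lies within the scatter of it, so the two compounds cannot be told apart on these data. For the measured compounds named here, no pair differing in one place has been measured, so no step size is known for the series.

Compound 3 `COc1ccc(-c2cn(-c3cccc(C(=O)/C=C/c4cc(OC)c(OC)c(OC)c4)c3)c(=O)[nH]2)cc1` is not yet measured. It differs from compound 1 by methoxy in place of chloro on an aromatic carbon. The swap is at the chloro position, para to a large group, and keeps the shared core intact. Going by the values given here, with no comparable step to go by, the expected step of a 1.1-fold higher number from compound 1 to compound 3 (0.03 log units; within the scatter) is none beyond the scatter. Compound 3 is therefore estimated at 1500 nM, range 600 nM to 3800 nM.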

Compound 3, concentration for 50% growth inhibition: 370 nM
Estimate against measurement, compound 3: 4.1-fold (0.61 log units) above; the measured number lies below the stated range.
By their numbers in this assay, from the lowest: compound 3; then compounds 2 and 1 (each within the scatter of the next).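

In this assay, for the compounds shown here, methoxy in place of chloro gives a 3.8-fold lower number from compound 1 to compound 3 (0.57 log units; beyond the scatter) and so supplies the first step beyond the scatter. The aromatic carbon para to a large group therefore responds to substitution, though this rests on one pair. No measurement shown accounts for the size of the step.

Open, as far as these compounds go, is whether an ethoxy group or an amine at this place moves the number further. Also open, from the compounds shown here alone, is whether 4-chlorophenyl to 4-methoxyphenyl gives a like step with the hydroxyphenyl end of compound 2.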